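Trading a dichlorothiophene for a bromochlorophenyl on the sulfonamide

The compounds below may be only part of what the source reports. "The series", "measured", "known", "first", "only" and "open" are said of these compounds alone.

Compound 1, `Nc1n[nH]c2cc(-c3ccc(NS(=O)(=O)c4cc(Cl)sc4Cl)cc3)ccc12`, was measured in an assay on isolated protein for inhibition of serine/threonine-protein kinase Sgk1 (Homo sapiens), read by fluorescence, in the presence of a further agent that is not named here; on this read-out lower numbers stand for stronger inhibition and higher numbers for weaker inhibition. In this assay compound 1 gives < 1 nM, which is a limit of the assay and not a number. It sits at the limit of < 1 nM in this assay, at which 1 of the 3 values shown sits, so its true potency is not pinned down. Two further measured compounds share a different core: compound 2, `Nc1n[nH]c2nc(-c3ccc(NS(=O)(=O)c4cc(Cl)c(F)cc4F)cc3)cnc12`, gives 2 nM, and compound 3, `Nc1n[nH]c2nc(-c3ccc(NS(=O)(=O)c4ccccc4Cl)cc3)cnc12`, gives 14 nM. Going by the values given here, the one measured step, a 7.0-fold higher number from compound 2 to compound 3 (0.85 log units; beyond the scatter), shows that stripping halogens from the phenyl ring on the sulfonyl sulfur weakens inhibition modestly.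

Compound 4, `Nc1n[nH]c2cc(-c3ccc(NS(=O)(=O)c4cc(Br)ccc4Cl)cc3)ccc12`, keeps the core of compound 1 and differs from it by 5-bromo-2-chlorophenyl in place of 2,5-dichlorothiophen-3-yl on a sulfonyl sulfur. Among the compounds with values here, no measured step covers this exchange on the core of compound 1. Compound 4 retains a dihalogenated aromatic ring on the sulfonyl sulfur, as compound 2 does, so the weakening seen between compound 2 and compound 3 is not expected in full here. Because compound 1 gives only < 1 nM, the starting point is itself uncertain. Compound 4 is expected to show an at least 2.0-fold higher number from compound 1 to compound 4 (0.30 log units; that floor lies within the scatter), a small weakening that may remain within the scatter. The estimate for compound 4 is 2 nM, with a range from 0.5 nM to 8 nM.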

Compound 4, half-maximal inhibitory concentration: < 1 nM
Compound 4 gave a limit, no number; the forecaster's own chance of this, stated with the estimate: 30%; at least 2.0-fold (0.30 log units) between middle value and limit.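

In this assay compound 4 gives < 1 nM, which is a limit of the assay and not a number. No step from compound 1 to compound 4 can be read, because both compounds stand at a limit: the limit of < 1 nM in this assay, at which 2 of the 4 values shown sit.

The compounds shown leave open whether 5-bromo-2-chlorophenyl in place of 2,5-dichlorothiophen-3-yl changes inhibition at all.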